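Bromo to chloro exchange: notes toward compound 4

The source may report more compounds than this note shows. Statements on the series, on what has been measured and on what is new or still open speak of the compounds shown alone.

Measured so far:
compound 1 `O=C(/C=C/c1ccc(Br)cc1)c1ccccc1O` 68.4%
compound 2 `O=C(/C=C/c1cccc(Br)c1)c1ccccc1O` 29.6%
compound 3 `O=C(/C=C/c1ccc(Cl)cc1)c1ccccc1O` 69.1%

All numbers come from a functional assay on HCT-116 cells (Homo sapiens) for cytotoxicity, read by MTT assay, with a stated time of 48 h, tested at 15 uM; on this read-out higher numbers stand for a weaker effect at the one concentration tested and lower numbers for a stronger effect. For the measured compounds named here, compound 1 gives 68.4% and compound 3 gives 69.1%; the step between them, a number 0.7 percentage points higher from compound 1 to compound 3 (within the scatter), is the only measured example of the change chloro in place of bromo on an aromatic carbon and lies within the scatter. Compound 2 gives 29.6%, the lowest of the three and beyond the scatter from both others. Compound 2 and compound 1 share the same atoms joined differently; the difference between the two cores is not broken down here.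

Compound 4 `O=C(/C=C/c1cccc(Cl)c1)c1ccccc1O` is not yet measured. It stands to compound 2 as compound 3 stands to compound 1: chloro in place of bromo on an aromatic carbon. The two place lines are not the same word for word, para to a large group in one case, meta to a large group in the other, so this is the same kind of change rather than the same change.

Going by the values given here, the expected step in this assay is a number 1.4 percentage points higher from compound 2 to compound 4 (within the scatter), set beside the measured a number 0.7 percentage points higher from compound 1 to compound 3 (within the scatter); it rests on that one step being within the scatter, and on the single low number of compound 2 29.6% as the starting point. Compound 4 is therefore estimated at 31%, with a range from 18% to 50% that allows for the one-point basis of the comparison.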

Compound 4, a percentage reported as activity, at one concentration (the size of the read-out at that concentration, not a potency): 37.5%
Compound 4: the middle estimate sits 6.5 percentage points below what was measured; the range from low to high includes it.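

In this assay, chloro in place of bromo on an aromatic carbon can now be read on two cores, and the new reading is a number 7.9 percentage points higher from compound 2 to compound 4 (within the scatter), which sets the two cores side by side: the same change on two cores in this assay, a number 0.7 percentage points higher (within the scatter) from compound 1 to compound 3 and a number 7.9 percentage points higher (within the scatter) from compound 2 to compound 4, 7.2 percentage points apart, within the scatter of two such steps. On these two cores the exchange therefore carries over, with compound 3 tracking compound 1 and compound 4 tracking compound 2, so chloro and bromo cannot be told apart at either place on this read-out. This does not show that the two groups are equivalent in general: it rests on just two pairs, each read at a single concentration, and a step within the scatter can still hide a small real difference, which these numbers can neither confirm nor exclude.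

The compounds shown leave open whether the exchange would hold for other groups at the same places, such as fluoro, methoxy, trifluoromethyl, an amine or a carboxylic acid, and whether it would hold on a core with other changes elsewhere in the molecule. They also leave open how the pairs would compare at other concentrations: each number gives only the size of the effect at the one concentration tested.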